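A Ring Swap on the Thiocarbonyl Carbon

The compounds below may be only part of what the source reports. "The series", "measured", "known", "first", "only" and "open" are said of these compounds alone.

Measured in a functional assay on KYSE-450 cells (Homo sapiens) for inhibition, read by CCK-8 assay, with a stated time of 48 h; on this read-out lower numbers stand for stronger inhibition and higher numbers for weaker inhibition:
compound 1 `COc1ccc(CN(C(=O)CSC(=S)N2CCN(C)CC2)c2cc(OC)c(OC)c(OC)c2)cc1`: 1250 nM
compound 2 `COc1ccc(CN(C(=O)CSC(=S)N2CCN(C(C)=O)CC2)c2cc(OC)c(OC)c(OC)c2)cc1`: 370 nM

Compound 1 stands as the higher of the two numbers. For the measured compounds named here, the only measured step, a 3.4-fold lower number from compound 1 to compound 2 (0.53 log units; beyond the scatter), changed just the group on the amine nitrogen in the ring. Compound 3 `COc1ccc(CN(C(=O)CSC(=S)N2CCc3cc(OC)ccc32)c2cc(OC)c(OC)c(OC)c2)cc1` differs from compound 1 more deeply: 5-methoxy-2,3-dihydro-1H-indol-1-yl in place of 4-methylpiperazin-1-yl on a thiocarbonyl carbon. Going by the values given here, no measured step tests this swap directly; the step to compound 2 shows only that altering this part of the molecule can shift the read-out modestly. Compound 3 is therefore expected to show a modest step, a 2.1-fold lower number from compound 1 to compound 3 (0.32 log units; beyond the scatter), with wide uncertainty. The estimate for compound 3 in this assay is 600 nM, ranging from 150 nM to 2500 nM.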

Compound 3, half-maximal inhibitory concentration: 10200 nM
Compound 3: middle estimate off by 17-fold (1.23 log units), on the low side; measured number above the stated range.
By their numbers in this assay, from the lowest: compound 2; then compound 1; then compound 3.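

Replacing the whole ring on the thiocarbonyl carbon shows that this position can also move the number upward, whereas the earlier change on the amine nitrogen had lowered it. 5-methoxy-2,3-dihydro-1H-indol-1-yl gives an 8.2-fold higher number from compound 1 to compound 3 (0.91 log units; beyond the scatter) in place of 4-methylpiperazin-1-yl and a 28-fold higher number from compound 2 to compound 3 (1.44 log units; beyond the scatter) in place of 4-acetylpiperazin-1-yl. Nothing available explains this rise. From the compounds shown here alone, it remains open whether the rise follows the fused ring system or its methoxy group, and how a morpholine ring or a dimethylamino group on this carbon would read.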